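The source may report more compounds than this note shows. Statements on the series, on what has been measured and on what is new or still open speak of the compounds shown alone.

Measured compounds:
compound 1, `CCCCNc1nn2c(=O)cc(C(F)(F)F)nc2s1`, 880 nM
compound 2, `Cc1ccc(-c2nn3c(=O)cc(C(F)(F)F)nc3s2)cc1C`, 540 nM

In an assay on cells for inhibition of alkaline phosphatase, tissue-nonspecific isozyme (Homo sapiens), read by luminescence, with stated times of 7 min and 20 min (a higher number here means a weaker inhibitor, a lower number a stronger inhibitor), compound 1 gives 880 nM, the higher of the two numbers recorded; compound 2 gives 540 nM, and the gap between the two lies within the scatter of this assay, so no order can be read from it. Compound 3, `O=c1cc(C(F)(F)F)nc2sc(-c3ccccc3F)nn12`, differs from compound 1 by a single change: 2-fluorophenyl in place of butylamino on an aromatic carbon. Going by the values given here, no pair of measured compounds shows exactly this exchange, so the step has to be judged from the two values at hand. Compound 2 also carries a six-membered aromatic ring of carbon only rather than an amino chain, and its value 540 nM sits close to that of compound 1. The step from compound 1 to compound 3 is therefore expected to be small, a 1.5-fold lower number from compound 1 to compound 3 (0.17 log units; within the scatter), not beyond the scatter. Compound 3 is estimated at 600 nM, with a range from 200 nM to 1800 nM.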

Compound 3, half-maximal inhibitory concentration: > 100000 nM
Compound 3: only a limit was reported (the forecaster's own chance of this, stated with the estimate: 5%); at least 160-fold (2.22 log units) between middle value and limit.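

In this assay compound 3 gives > 100000 nM, which is a limit of the assay and not a number. At this aromatic carbon, the exchange of butylamino for 2-fluorophenyl is therefore far from neutral, with an at least 110-fold higher number from compound 1 to compound 3 (2.05 log units; beyond the scatter). Compound 2 also carries a six-membered aromatic ring of carbon only at this carbon and gives 540 nM, so such a ring alone does not account for the loss seen with compound 3. The size of the step to compound 3 is only a bound: the limit of > 100000 nM in this assay, at which 1 of the 3 values shown sits.

The compounds shown leave open whether the loss goes with the fluorine itself, which plain phenyl or a chlorophenyl would help to settle. They also leave open how a shorter chain such as ethylamino, or a free amine, would read at this carbon.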